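From compound 3 to compound 4: a new aromatic group

A few compounds are considered here, and "the series" means these few. Any claim that something is new, unique, unknown or untested is made for them only; others in the source may bear on it.

In an ADME assay on HEK293 cells (Homo sapiens) for cytotoxicity, read by MTT assay, with a stated time of 24 h (a higher number here means a weaker inhibitor, a lower number a stronger inhibitor), three compounds share one core and differ in the aromatic group on a saturated chain carbon bound to a nitrogen on an aromatic ring. Compound 1 `Cc1ccc(CNc2nc3ccc([N+](=O)[O-])cc3nc2NCCCN(C)C)cc1` gives 15.8 ug/mL, compound 2 `CN(C)CCCNc1nc2cc([N+](=O)[O-])ccc2nc1NCc1ccccc1Br` gives 51.9 ug/mL, and compound 3 `Cc1ccccc1CNc1nc2ccc([N+](=O)[O-])cc2nc1NCCCN(C)C` gives 27.6 ug/mL. Compound 3 stands within the scatter of both others: the measured steps are a 1.7-fold higher number from compound 1 to compound 3 (0.24 log units; within the scatter) and a 1.9-fold lower number from compound 2 to compound 3 (0.27 log units; within the scatter).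

The next compound is compound 4 `CN(C)CCCNc1nc2cc([N+](=O)[O-])ccc2nc1NCc1ccc(Cl)c(C(F)(F)F)c1`, and the change is 4-chloro-3-(trifluoromethyl)phenyl in place of 2-methylphenyl on a saturated chain carbon bound to a nitrogen on an aromatic ring. In words, 4-chloro-3-(trifluoromethyl)phenyl takes the place of 2-methylphenyl. Among the compounds with values here, no measured compound carries this new group, so the three steps bear on it only as a guide to how far a swap at this place has moved the number. Two of them stay within the scatter, and the largest, a 3.3-fold higher number from compound 1 to compound 2 (0.52 log units; beyond the scatter), is modest. Together they give no direction for the new group, so no step beyond the scatter is expected. The estimated change is a 1.3-fold lower number from compound 3 to compound 4 (0.10 log units; within the scatter). For compound 4 the estimated value is 22 ug/mL, with an expected range from 9 ug/mL to 50 ug/mL.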

Compound 4, half-maximal inhibitory concentration: 3.26 ug/mL
Estimate against measurement, compound 4: 6.7-fold (0.83 log units) above; measured number outside the range, below it.
By their numbers in this assay, from the lowest: compound 4; then compounds 1, 3 and 2 (each within the scatter of the next, the first and the last beyond it).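

In this assay the new group gives an 8.5-fold lower number from compound 3 to compound 4 (0.93 log units; beyond the scatter) together with a 4.8-fold lower number from compound 1 to compound 4 (0.69 log units; beyond the scatter) and a 16-fold lower number from compound 2 to compound 4 (1.20 log units; beyond the scatter) in the same direction, so compound 4 has the lowest number of the four and stands beyond the scatter of each of the others. Among the earlier compounds, the one step beyond the scatter was a 3.3-fold higher number from compound 1 to compound 2 (0.52 log units; beyond the scatter) and it pointed upward, so only now is it clear that a swap at this place can also take the number well down, and further than any earlier swap moved it. Nothing measured here explains why the number falls with this group.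

The new group brings chloro and trifluoromethyl onto the phenyl ring at once, so the compounds shown cannot separate their shares in the step; a 4-chlorophenyl group and a 3-(trifluoromethyl)phenyl group, each tested alone at this place, would do that. Also open, on these data alone, is whether a similar step appears with a pyridine ring here in place of the phenyl ring, or with the same group on a core carrying a longer chain in place of the dimethylaminopropyl chain.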